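The compounds below may be only part of what the source reports. "The series", "measured", "known", "first", "only" and "open" are said of these compounds alone.

Of the compounds shown here, two from this series have been tested in an ADME assay on cells (Hepatocyte, Homo sapiens) for cytotoxicity, read by MTT assay, with a stated time of 90 min, tested at 200 uM; a lower number here means a stronger effect, a higher number a weaker effect of the compound at the concentration tested. Compound 2 `Cc1c(C)c2c(c(C)c1CCCCCCNC(=O)OCc1ccccc1)CCC(C)(COc1ccc(/C=C3\SC(=O)NC3=O)cc1)O2` gives 80.3% in this assay. Compound 1 `Cc1c(C)c2c(c(C)c1OC(=O)CCCCCCCNC(=O)OC(C)(C)C)CCC(C)(COc1ccc(/C=C3\SC(=O)NC3=O)cc1)O2`, which carries a different chain on the shared core, gives 74.7% in this assay. The two numbers lie within the usual scatter of each other, so on what has been measured compound 2 stands together with compound 1 rather than apart from it, and neither can be called the weaker or the stronger of the pair.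

The next compound, compound 3 `Cc1c(C)c2c(c(C)c1CCCCCCN)CCC(C)(COc1ccc(/C=C3\SC(=O)NC3=O)cc1)O2`, is reached from compound 2 by a single change: hydrogen in place of benzyloxycarbonyl on an amine nitrogen. Within the data shown here, no measured pair in the set shows what this kind of change does in this assay, so there is no step to lean on. Given that compound 2 gives 80.3% and that compound 1 gives 74.7% with a different chain, the expectation is a step from compound 2 to compound 3 of a number 0.3 percentage points lower from compound 2 to compound 3 (within the scatter), which is no change beyond the scatter. Compound 3 is therefore expected to give about 80% in this assay, within a range from 62% to 98%.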

Compound 3, a percentage reported as activity, at one concentration (the size of the read-out at that concentration, not a potency): 79.9%
The estimate for compound 3 lay 0.1 percentage points above the measured number; measured number inside the range.
By their numbers in this assay, from the lowest: compounds 1, 3 and 2 (each within the scatter of the next).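

Compounds 2 and 3 give the series its first pair that differs in one place, and in this assay hydrogen in place of benzyloxycarbonyl on an amine nitrogen amounts to a number 0.4 percentage points lower from compound 2 to compound 3 (within the scatter), so the two compounds stand together. On this single pair, the amine nitrogen of this chain can lose the whole benzyloxycarbonyl group, with its 10 heavy atoms and its six-membered aromatic ring of carbon only, without a step beyond the scatter in this read-out at the one concentration tested. Nothing available explains why the two compounds read alike.

One pair cannot show whether the same holds for other groups on this nitrogen, such as acetyl or a benzoyl amide, or for a carboxylic acid in place of the amine, a shorter chain or a longer chain. It also leaves open whether the same change would give a similar step on the ester-linked chain of compound 1, since that chain has no counterpart carrying the free amine among the compounds shown.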